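Trimming the ether chain on a chloro-substituted core

The compounds below may be only part of what the source reports. "The series", "measured", "known", "first", "only" and "open" are said of these compounds alone.

Compound 1 `CC(C)COc1ccc2c(Cl)ccnc2c1` is the weakest of the three compounds measured in a functional assay on HCT-116 cells (Homo sapiens) for cytotoxicity, read by MTT assay, with a stated time of 48 h; a lower number here means a stronger inhibitor, a higher number a weaker inhibitor: compound 1 gives 2490 nM. The two compounds that carry an aminoalkylamino group in place of the chlorine sit lower; compound 2 `CN(C)CCCNc1ccnc2cc(OCc3ccc(F)cc3)ccc12` gives 740 nM and compound 3 `CCCCCCOc1ccc2c(NCCN(C)C)ccnc2c1` gives 850 nM. Both of these gaps to compound 1 lie beyond the usual scatter of the assay, so compound 1 stands apart at the top of the range.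

Compound 4 `C=CCOc1ccc2c(Cl)ccnc2c1` keeps the chlorine and the core of compound 1 and changes only the ether chain: vinyl in place of isopropyl on a saturated chain carbon bound to an oxygen on an aromatic ring. Going by the values given here, no measured pair shows a change of this kind; compounds 2 and 3 differ from compound 1 in more than one place, so nothing among the measured compounds isolates the chain as a lever. The step from compound 1 to compound 4 is therefore expected to be small, a 1.0-fold higher number from compound 1 to compound 4 (0.00 log units; within the scatter), in no particular direction and not beyond the scatter. Compound 4 is expected to give 2500 nM in this assay, within a range from 1200 nM to 5500 nM.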

Compound 4, half-maximal inhibitory concentration: 2570 nM
The estimate for compound 4 lay 1.0-fold (0.01 log units) below the measured number, within the range that was stated.
By their numbers in this assay, from the lowest: compounds 2 and 3 (each within the scatter of the next); then compounds 1 and 4 (each within the scatter of the next).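

Among the compounds shown, the change from isobutoxy to allyloxy is the first to isolate the ether chain while the chlorine and the rest of the core of compound 1 stay fixed, and in this assay it comes to a 1.0-fold higher number from compound 1 to compound 4 (0.01 log units; within the scatter), a step within the scatter. At this place, on a saturated chain carbon bound to an oxygen on an aromatic ring, isopropyl and vinyl therefore cannot be told apart in this assay, even though vinyl brings a double bond outside aromatic rings; this single pair says nothing about other groups at that place or about the same change on a core that carries an aminoalkylamino group. No measurement at hand accounts for this result.

Steps linking compound 2 or compound 3 to the chlorine-bearing compounds cannot be read, as those compounds differ from them in more than one place, so neither the chlorine nor the aminoalkylamino group has been assessed on its own. As far as these compounds go, it also remains open whether the number would move if the ether chain ended in a carboxylic acid or a morpholine ring.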